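Trading dimethyl for chloro and trifluoromethyl on the aryl group

The source may hold more compounds than are shown below. What is called first, only, known or untested is meant among the compounds shown, and "the series" means these compounds.

Compound 3 (`Cc1cc(C)cc(Nc2ncc(C(F)(F)F)c(N3Cc4cccc(N(C)S(C)(=O)=O)c4C3)n2)c1`) gives > 30000 nM in a functional assay on U-87MG ATCC cells for antiproliferative activity against U-87 MG (Homo sapiens), read by spectrophotometry, with a stated time of 2 days (a lower number here means a stronger inhibitor of growth, a higher number a weaker inhibitor of growth), and this is a limit of the assay, not a number. Compound 2 (`Cc1cc(F)ccc1Nc1ncc(C(F)(F)F)c(N2Cc3cccc(N(C)S(C)(=O)=O)c3C2)n1`) gives > 30000 nM and this too is only a limit. The set therefore shows the limit of > 30000 nM in this assay, at which 2 of the 3 values shown sit, and a single true number. Compound 1 (`COc1cc(Nc2ncc(C(F)(F)F)c(N3Cc4cccc(N(C)S(C)(=O)=O)c4C3)n2)c(OC)cc1Cl`) supplies that number at 6200 nM and carries a chlorine on the group that varies.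

The change to compound 4 (`CN(c1cccc2c1CN(c1nc(Nc3cc(Cl)cc(C(F)(F)F)c3)ncc1C(F)(F)F)C2)S(C)(=O)=O`) is 3-chloro-5-(trifluoromethyl)phenyl in place of 3,5-dimethylphenyl on a nitrogen on an aromatic ring and it puts 3-chloro-5-(trifluoromethyl)phenyl in place of 3,5-dimethylphenyl on a nitrogen on an aromatic ring, leaving the shared core untouched. Among the compounds with values here, two measured steps bear on it: an at least 4.8-fold higher number from compound 1 to compound 3 (0.68 log units; beyond the scatter) and an at least 4.8-fold higher number from compound 1 to compound 2 (0.68 log units; beyond the scatter) both lie beyond the scatter and both lead away from the group of compound 1. The remaining step gives no size: a step that the two limits leave unreadable from compound 2 to compound 3 is all that can be said of it. Compound 4 regains a chlorine like that of compound 1 (6200 nM) and so a modest move toward a lower number is expected. Another reading at the limit remains quite possible for compound 4. The expected step is an at least 2.1-fold lower number from compound 3 to compound 4 (0.33 log units; beyond the scatter) and it points toward stronger growth inhibition. For compound 4 the estimated value is 14000 nM with 4000 nM to 35000 nM as the expected range.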

Compound 4, concentration for 50% growth inhibition: 5500 nM
The estimate for compound 4 lay 2.5-fold (0.41 log units) above the measured number; the measured number falls inside the stated range.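

Setting 3-chloro-5-(trifluoromethyl)phenyl on this nitrogen gives an at least 5.4-fold lower number from compound 3 to compound 4 (0.73 log units; beyond the scatter) and, in place of 4-fluoro-2-methylphenyl, an at least 5.4-fold lower number from compound 2 to compound 4 (0.73 log units; beyond the scatter), so in this assay a true number at this position no longer depends on the two methoxy groups of compound 1. The new group and 4-chloro-2,5-dimethoxyphenyl cannot be told apart here, the step being a 1.1-fold lower number from compound 1 to compound 4 (0.05 log units; within the scatter). Among these compounds, the two aryl groups that give a true number both carry chlorine and the two without it do not give one, with no compound going against this pattern, though it rests on very few true numbers: the limit of > 30000 nM in this assay, at which 2 of the 4 values shown sit.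

Going by these compounds, the step between compound 2 and compound 3 cannot be read, as both values are limits, and compound 4 brings in chlorine and trifluoromethyl together, so the share of each stays unknown. On these data alone, it also remains open how a plain 3-chlorophenyl, a 3,5-dichlorophenyl or a 3-(trifluoromethyl)phenyl group would read at this position, and whether an amine or a carboxylic acid on the aryl ring would keep a true number.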